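Nitro in Place of Hydroxy on the Arylhydrazone

This account rests on a few compounds, and the source may have more. Where it says the series, first, only, none or still open, it means among the compounds named here.

Measured compounds:
- compound 1, `CC1CC/C(=N\Nc2ccccc2O)c2ncc(C(=O)O)c(=O)n21`: 0.26 umol/kg
- compound 2, `CC1CC/C(=N\Nc2ccc(O)cc2)c2ncc(C(=O)O)c(=O)n21`: 1.7 umol/kg
- compound 3, `Cc1cccc(N/N=C2\CCC(C)n3c2ncc(C(=O)O)c3=O)c1`: 0.4 umol/kg

These three compounds share one core and differ only in the aromatic ring attached to the amine nitrogen. In a functional assay on the whole organism for inhibition, with Rattus norvegicus as the target (on this read-out lower numbers stand for an effect already at smaller amounts and higher numbers for an effect only at larger amounts of compound), compound 2 gives the highest of the three numbers; its nearest neighbour is compound 3, and the furthest is compound 1. Both steps out of compound 2 go beyond the scatter: a 6.5-fold higher number from compound 1 to compound 2 (0.82 log units; beyond the scatter), and a 4.3-fold lower number from compound 2 to compound 3 (0.63 log units; beyond the scatter). The step of a 1.5-fold higher number from compound 1 to compound 3 (0.19 log units; within the scatter) stays within the scatter.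

Compound 4, `CC1CC/C(=N\Nc2ccc([N+](=O)[O-])cc2)c2ncc(C(=O)O)c(=O)n21`, keeps the core and the ring of compound 2 and changes one group: nitro in place of hydroxy on an aromatic carbon. Going by the values given here, no measured step involves a nitro group, so the only guidance is that the two steps touching compound 2 both point away from its number. The change here leaves that same hydroxy behind, which suggests a modest move in the same direction rather than a large one, although the size is uncertain.

Compound 4 is therefore expected to give 0.8 umol/kg in this assay, with a range of 0.25 umol/kg to 2.5 umol/kg, corresponding to an expected step of a 2.1-fold lower number from compound 2 to compound 4 (0.33 log units; beyond the scatter).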

Compound 4, dose for 50% inhibition: 0.8 umol/kg
Beside the measured number, compound 4's estimate shows no gap at the digits printed, within the range that was stated.
By their numbers in this assay, from the lowest: compounds 1, 3 and 4 (each within the scatter of the next, the first and the last beyond it); then compound 2.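

In this assay the hydroxy of compound 2 proves replaceable at this place, para to a large group, since a 2.1-fold lower number from compound 2 to compound 4 (0.33 log units; beyond the scatter) comes with nitro in its stead, a group with 0 hydrogen-bond donors and more heavy atoms than the hydroxy it replaces. The earlier steps shown here exchanged one substituted phenyl for another, so each altered the place of the substituent or its identity in ways that could not be told apart, whereas this step keeps the place fixed and changes only the group, and the number still moves beyond the scatter. Nothing in the data accounts for this step, which therefore stands as an observed difference in size and direction, with no explanation attached.

With only hydroxy and nitro shown at this place, it remains open how an amine, a carboxylic acid or a methoxy group would fare there, and so whether the lower number of compound 4 belongs to nitro alone. As far as these compounds go, it is also open what nitro would do at the place that the hydroxy occupies in compound 1, or at the place of the methyl in compound 3.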